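Moving the methyl on the phenoxy ring

The source may hold more compounds than are shown below. What is called first, only, known or untested is meant among the compounds shown, and "the series" means these compounds.

Compound 1 `Cc1cccc(N(C)C(=O)c2ccc(Oc3ccccc3C)cc2)c1` is recorded in an assay for inhibition of 17-beta-hydroxysteroid dehydrogenase type 1 (Homo sapiens), read by HPLC, with a stated time of 10 min (a higher number here means a weaker inhibitor, a lower number a stronger inhibitor), as "not active" (no number reported), so no number places it on the scale. Within the data shown here, the only numbered relative is compound 2 `COc1ccc(Oc2ccc(C(=O)N(C)c3cccc(OC)c3)cc2)cc1`, which in this assay gives 9600 nM. Compound 3 `Cc1cccc(Oc2ccc(C(=O)N(C)c3cccc(C)c3)cc2)c1` differs from compound 1 by 3-methylphenyl in place of 2-methylphenyl on an oxygen on an aromatic ring. Among the measured compounds shown here, no measured step covers this change; at most a modest move toward a measurable but weak number in this assay is expected, and another inactive reading remains quite possible. Compound 3 is estimated at 8000 nM in this assay, within 2000 nM to 40000 nM.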

Compound 3, half-maximal inhibitory concentration: 16100 nM
Estimate against measurement, compound 3: 2.0-fold (0.30 log units) below; the measured number falls inside the stated range.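

Among these compounds, compound 1 at "not active" (no number reported) and compound 3 at 16100 nM in this assay give no step that can be read. No evidence on hand bears on this result. Still open, from the compounds shown here alone, is how far 3-methylphenyl in place of 2-methylphenyl shifts inhibition on the shared core.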